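Lengthening the Alkyl Chain on a Dithiocarbamate Lactone

The source may report more compounds than this note shows. Statements on the series, on what has been measured and on what is new or still open speak of the compounds shown alone.

Among the compounds with values here, compound 2 `CCCCCCCCSC(=S)N[C@H]1CCOC1=O` gives 65100 nM in a functional assay on SMMC-7721 cells (Homo sapiens) for cytotoxicity, read by MTT assay, with a stated time of 72 h (on this read-out higher numbers stand for weaker inhibition and lower numbers for stronger inhibition), and stands as the only number among the two values shown. Compound 1 `CCSC(=S)N[C@H]1CCOC1=O` gives only a limit in this assay, > 128000 nM. On these data alone, the step of an at least 1.9-fold lower number from compound 1 to compound 2 (0.29 log units; that floor lies within the scatter) rests on that limit (the limit of > 128000 nM in this assay, at which 1 of the 2 values shown sits), so its true size is unknown. Compound 3 `CCCCCCCCCCCCCCSC(=S)N[C@H]1CCOC1=O` differs from compound 2 by hexyl in place of hydrogen on a saturated chain carbon, eight bonds along the chain from a sulfur. Within the data shown here, only the step from compound 1 to compound 2 bears on this change, and its floor sits within the scatter, so a modest move toward a lower number is expected at best. The expected step is a 1.9-fold lower number from compound 2 to compound 3 (0.27 log units; within the scatter). Compound 3 is estimated at 35000 nM, between 10000 nM and 128000 nM.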

Compound 3, half-maximal inhibitory concentration: 56800 nM
For compound 3 the middle estimate is 1.6-fold (0.21 log units) below the measured one, and the stated range covers the measured number.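

In this assay, hexyl in place of hydrogen on a saturated chain carbon, eight bonds along the chain from a sulfur, gives a 1.1-fold lower number from compound 2 to compound 3 (0.06 log units; within the scatter). Within the data shown here, this is the first step here with a measured number at both ends, and it shows that this further lengthening of the chain leaves the read-out within the scatter. Compound 1 gives only a limit, so the size of the earlier step along this chain stays unknown: the limit of > 128000 nM in this assay, at which 1 of the 3 values shown sits.

On these data alone, whether an amine or a carboxylic acid on this chain, or a still longer chain, would move the number stays open.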